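This account rests on a few compounds, and the source may have more. Where it says the series, first, only, none or still open, it means among the compounds named here.

Measured so far:
- compound 1, `O=C(O)/C(S)=C/c1ccccc1Cl`: 20700 nM
- compound 2, `O=C(O)/C(S)=C/c1c[nH]c2cc(I)ccc12`: 300 nM

Both numbers come from an assay on isolated protein for inhibition of Calpain-1 catalytic subunit (Sus scrofa); on this read-out higher numbers stand for weaker inhibition and lower numbers for stronger inhibition. Of the two, compound 1 carries the higher number; compound 2 sits well below it, a gap that lies beyond the usual scatter of this assay, so compound 1 is the weaker inhibitor of the pair. Compound 3, `O=C(O)/C(S)=C/c1ccccc1Br`, has not yet been measured in this assay. It differs from compound 1 in one place: bromo in place of chloro on an aromatic carbon. One halogen is exchanged for another at the same spot on the six-membered carbon ring, and no other part of the shared core changes. Among the measured compounds shown here, a swap of this kind is small, and no measured pair here shows what it does. The expected change in this assay is therefore none beyond the scatter, estimated at a 1.3-fold lower number from compound 1 to compound 3 (0.11 log units; within the scatter). Compound 3 is expected to give about 16000 nM, within a range from 6000 nM to 45000 nM.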

Compound 3, half-maximal inhibitory concentration: 9100 nM
Estimate against measurement, compound 3: 1.8-fold (0.25 log units) above; low and high end bracket the measured number.
By their numbers in this assay, from the lowest: compound 2; then compound 3; then compound 1.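

Swapping chloro for bromo on this aromatic carbon in this assay gives a 2.3-fold lower number from compound 1 to compound 3 (0.36 log units; beyond the scatter) and so shows that this position responds to which halogen it carries, even though each group counts a single heavy atom. Among the compounds shown here, the step is modest, but it is the first direct reading at this spot, since the earlier compounds offered no pair differing in one place. Nothing measured here accounts for the lower number with bromo.

Going by these compounds, whether iodo at the same position would continue this trend remains open, as does what a group other than a halogen, such as methyl, methoxy or an amine, would do there. On these data alone, it is also open whether the same swap would have a similar effect on a different core.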